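The source may hold more compounds than are shown below. What is called first, only, known or untested is meant among the compounds shown, and "the series" means these compounds.

Compound 1 `COc1cc(N)c(Cl)cc1NC(=O)C1CCN(C/C=C/c2ccccc2)CC1` in a functional assay on the whole organism for antagonist activity, with Mus musculus as the target (on this read-out higher numbers stand for an effect only at larger amounts of compound and lower numbers for an effect already at smaller amounts), gives > 10 mg/kg, which is a limit of the assay rather than a number.
Compound 2 `COc1cc(N)c(Cl)cc1NC(=O)C1CCN(Cc2ccc(Cl)cc2)CC1` gives 1.2 mg/kg.
Compound 3 `COc1cc(N)c(Cl)cc1NC(=O)C1CCN(Cc2ccccc2)CC1` gives 0.5 mg/kg.

Compound 3 thus holds the lowest of the two numbers; the nearest number belongs to compound 2, and a 2.4-fold lower number from compound 2 to compound 3 (0.38 log units; beyond the scatter).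

Compound 4 `COc1cc(N)c(Cl)cc1NC(=O)C1CCN(Cc2ccsc2)CC1` differs from compound 3 by thiophen-3-yl in place of phenyl on a saturated chain carbon bound to an amine nitrogen in a ring. The measured steps at this position are an at least 8.3-fold lower number from compound 1 to compound 2 (0.92 log units; beyond the scatter) and an at least 20-fold lower number from compound 1 to compound 3 (1.30 log units; beyond the scatter); both replace the 2-phenylethenyl chain by an aromatic ring directly on that carbon, and neither involves a five-membered ring, so they bear on the present exchange only loosely. Swapping one aromatic ring for another is expected to leave this assay close to compound 3, so a 1.2-fold higher number from compound 3 to compound 4 (0.08 log units; within the scatter) is the expected step. Compound 4 is therefore estimated at 0.6 mg/kg in this assay, within 0.25 mg/kg to 1.5 mg/kg.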

Compound 4, dose for half-maximal effect: 3.4 mg/kg
Compound 4: the middle estimate sits 5.7-fold (0.75 log units) below what was measured, outside the stated range (above it).
By their numbers in this assay, from the lowest: compound 3; then compound 2; then compound 4. At a limit, above all of these: compound 1.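

Even among aromatic rings, the choice on this carbon matters in this assay where thiophen-3-yl in place of phenyl gives a 6.8-fold higher number from compound 3 to compound 4 (0.83 log units; beyond the scatter) and so does not stand in for it. Compound 4 also trails the chlorinated ring, with a 2.8-fold higher number from compound 2 to compound 4 (0.45 log units; beyond the scatter) and both six-membered aromatic rings shown thus give lower numbers than the thiophene. It still improves on the 2-phenylethenyl chain, with an at least 2.9-fold lower number from compound 1 to compound 4 (0.46 log units; beyond the scatter) but compound 1 stands at a limit of the assay: the limit of > 10 mg/kg in this assay, at which 1 of the 4 values shown sits.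
The compounds shown leave open how thiophen-2-yl, furan-3-yl or a pyridine ring would behave on this carbon.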